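A Single Methyl Added to Compound 3

The source may report more compounds than this note shows. Statements on the series, on what has been measured and on what is new or still open speak of the compounds shown alone.

compound 1 `Nc1sc2c(c1C(=O)c1ccc(Cl)c3ccccc13)CCC2`: 0%
compound 2 `Nc1sc2c(c1C(=O)c1ccc(Cl)c3ccccc13)CCCC2`: 30.5%
compound 3 `Nc1sc2c(c1C(=O)c1ccc3ccccc3c1)CCC2`: 54%

In an assay on isolated protein with adenosine receptor A3 (Homo sapiens) as the target, tested at 10 uM (on this read-out higher numbers stand for more inhibition at the one concentration tested (going by the name of the read-out) and lower numbers for less inhibition), compound 3 gives 54%, the highest of the three numbers. Compound 2 gives 30.5%, a value lower by more than the usual scatter, and compound 1 gives 0%, lower still. Compound 4 `Cc1cc(C(=O)c2c(N)sc3c2CCC3)cc2ccccc12` differs from compound 3 in one place: methyl in place of hydrogen on an aromatic carbon. Among the compounds with values here, no pair of measured compounds shows what such a change does, so the expectation rests on compound 3 alone. In this assay a small step is expected from compound 3 to compound 4, in either direction and probably not beyond the scatter, estimated as a number 4 percentage points lower from compound 3 to compound 4 (within the scatter). Compound 4 is therefore expected to give about 50%, within a range from 20% to 80%.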

Compound 4, a percentage reported as inhibition, at one concentration (the size of the read-out at that concentration, not a potency): 0%
Beside the measured number, compound 4's estimate is 50 percentage points above it, and the stated range ends above it.
By their numbers in this assay, from the lowest: compounds 1 and 4 (each within the scatter of the next); then compound 2; then compound 3.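

In this assay, methyl in place of hydrogen on this aromatic carbon gives a number 54 percentage points lower from compound 3 to compound 4 (beyond the scatter). Within the data shown here, this is the first single change with a measured effect, and it shows that one added carbon at this position can remove all the inhibition seen for compound 3 at the one concentration tested. Nothing measured here explains the loss.

From the compounds shown here alone, whether fluorine, a methoxy group or an amine at this position would have the same effect stays open. So does whether methyl on another carbon of this ring would.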